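A fluoropyridine amide after two pyridine amides

The compounds below may be only part of what the source reports. "The series", "measured", "known", "first", "only" and "open" are said of these compounds alone.

In a physicochemical assay for solubility, measured as kinetic solubility, with a stated time of 1 h, at pH 7.4 (on this read-out lower numbers stand for lower solubility and higher numbers for higher solubility), compound 1 `O=C(NC1=NN(c2ccc(Cl)c(Cl)c2)CC1)c1cccnc1` gives 4000 nM and compound 2 `O=C(NC1=NN(c2ccc(Cl)c(Cl)c2)CC1)c1ccccn1` gives 11000 nM, the higher of the two numbers. Compound 3 `O=C(NC1=NN(c2ccc(Cl)c(Cl)c2)CC1)c1cccnc1F` has 2-fluoropyridin-3-yl in place of pyridin-2-yl on a carbonyl carbon. For the measured compounds named here, the only measured step that bears on this is the modest 2.8-fold higher number from compound 1 to compound 2 (0.44 log units; beyond the scatter). Going by the values given here, compound 3 returns to a pyridin-3-yl name, as in compound 1, but no measured compound carries fluorine, so a modest fall of similar size is expected. The expected change is a 2.2-fold lower number from compound 2 to compound 3 (0.34 log units; beyond the scatter). For compound 3 the estimated value is 5000 nM, with an expected range of 2000 nM to 12000 nM.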

Compound 3, solubility: 13000 nM
Estimate against measurement, compound 3: 2.6-fold (0.41 log units) below; measured number above the stated range.
By their numbers in this assay, from the lowest: compound 1; then compounds 2 and 3 (each within the scatter of the next).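

In this assay, fluoro in place of hydrogen on an aromatic carbon gives a 3.3-fold higher number from compound 1 to compound 3 (0.51 log units; beyond the scatter) and so moves the number on the pyridin-3-yl amide. Set against the pyridin-2-yl amide, 2-fluoropyridin-3-yl gives a 1.2-fold higher number from compound 2 to compound 3 (0.07 log units; within the scatter) and so the two groups cannot be told apart on this read-out. No measurement at hand explains the effect of the fluoro. On these data alone, whether a chloro, a methoxy or an amine in place of the fluoro would give a similar number remains open. So does whether fluoro would have a similar effect on the pyridin-2-yl amide.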